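The source may report more compounds than this note shows. Statements on the series, on what has been measured and on what is new or still open speak of the compounds shown alone.

Compound 1 `COc1cccc(Oc2ccc3c(NCCCNCc4cc(F)ccc4OC)ccnc3c2)c1` is measured in a physicochemical assay for acid dissociation, where compound 1 gives 9.28. Two related compounds are measured alongside it. Compound 2 `COc1cccc(Oc2ccc3c(NCCCNCc4cccc(OC)c4O)ccnc3c2)c1` gives 9.28, and compound 3 `c1coc(CNCCCNc2ccnc3cc(CC4CCCCC4)ccc23)c1` gives 9.47. Between compound 1 and compound 2 there is a single change, 2-hydroxy-3-methoxyphenyl in place of 5-fluoro-2-methoxyphenyl on a saturated chain carbon bound to an amine nitrogen, and the step of no change at the digits printed from compound 1 to compound 2 (within the scatter). Compound 1 thus stands level with compound 2 at the digits shown, the two together the lowest of the three numbers, while compound 3 sits somewhat higher, though still within the scatter.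

Compound 4 `COc1ccc(F)cc1CNCCCNc1ccnc2cc(-c3cccc4ccccc34)ccc12` has not yet been measured. Its change from compound 1 is naphthalen-1-yl in place of 3-methoxyphenoxy on an aromatic carbon. Going by the values given here, no measured step alters a group on the aromatic carbon of the shared core in this way; the one measured step concerns the chain end, and was flat. Compound 3, which differs from compound 1 in several places, also stays within the scatter. So for compound 4 a step of a number 0.02 log units higher from compound 1 to compound 4 (within the scatter) is expected, essentially none beyond the scatter. Compound 4 is estimated at 9.3, between 9 and 9.6.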

Compound 4, acid dissociation constant: 9.47
The estimate for compound 4 lay 0.17 log units below the measured number, and the stated range covers the measured number.
By their numbers in this assay, from the lowest: compounds 1, 2, 3 and 4 (each within the scatter of the next).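

In this assay, going by these compounds alone, putting naphthalen-1-yl in place of 3-methoxyphenoxy on this aromatic carbon gives a number 0.19 log units higher from compound 1 to compound 4 (within the scatter), the first measured step at this position of the shared core. The reading stays within the scatter although the groups differ in what they carry: the leaving group has one six-membered aromatic ring of carbon only and 2 hydrogen-bond acceptors, the entering group 2 such rings and 0 hydrogen-bond acceptors. Nothing measured for these compounds gives a reason for this result.

The compounds shown leave open whether a group of another kind on this aromatic carbon, such as an amine or a carboxylic acid, would also stay within the scatter. A single step also cannot show whether the same swap would read alike with the 2-hydroxy-3-methoxyphenyl group of compound 2 at the chain end.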